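The compounds below may be only part of what the source reports. "The series", "measured", "known", "first", "only" and "open" are said of these compounds alone.

Compound 1, `COC1CN(C(=O)/C=C/c2ccncc2-c2ccc3[nH]ncc3c2)C1`, gives 98% in an assay on a protein complex for inhibition of CDK8/Cyclin C (Homo sapiens), with a stated time of 1 h, tested at 10 uM; a higher number here means more inhibition at the concentration tested (going by the name of the read-out), a lower number less inhibition. Compound 2, `COC1CN(C(=O)/C=C/c2ccncc2-c2ccc3ccccc3c2)C1`, gives 100% in this assay. Compound 3, `CNC(=O)CCc1ccncc1-c1ccc2ccccc2c1`, gives 100% in this assay.

On these numbers compound 3 stands level with compound 2 at the digits shown, the two together the highest of the three, and compound 1 sits within the scatter of both, so no order among them can be read. Compound 4, `O=C(O)COc1ccncc1-c1ccc2ccccc2c1`, differs from compound 3 in one place: carboxymethoxy in place of 2-(methylcarbamoyl)ethyl on an aromatic carbon. Going by the values given here, no measured pair shows what such an exchange does in this assay. The account expects a modest loss for compound 4, a step from compound 3 to compound 4 of a number 15 percentage points lower from compound 3 to compound 4 (beyond the scatter), possibly beyond the scatter. Compound 4 is estimated at 85%, within 55% to 100%.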

Compound 4, a percentage reported as inhibition, at one concentration (the size of the read-out at that concentration, not a potency): 16%
Estimate against measurement, compound 4: 69 percentage points above; measured number below the stated range.
By their numbers in this assay, from the lowest: compound 4; then compounds 1, 2 and 3 (each within the scatter of the next).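

In this assay, the group on this aromatic carbon opposite the ring nitrogen proves decisive for the read-out: carboxymethoxy in place of 2-(methylcarbamoyl)ethyl gives a number 84 percentage points lower from compound 3 to compound 4 (beyond the scatter). Going by these compounds alone, this is the first difference beyond the scatter, so the position does not accept every chain of similar size. Nothing measured here accounts for the loss. The compounds shown leave open whether the ether oxygen or the terminal acid carries the loss. A methyl ester on the same chain, or a carboxylic acid on an all-carbon chain, would separate the two.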